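The compounds below may be only part of what the source reports. "The series", "measured", "known", "first", "only" and "open" are said of these compounds alone.

Measured in an ADME assay on microsomes from liver (Rattus norvegicus) for metabolic stability, read by LC-MS, using NADPH, with a stated time of 1 h, tested at 10 uM; on this read-out lower numbers stand for slow clearance and higher numbers for fast clearance:
- compound 1 `Cn1nc(CN2CCCC2)nc1-c1ccc(C2(C(F)(F)F)CC2)cc1`: 207 mL.min-1.g-1
- compound 2 `Cn1nc(CN2CCCC2)nc1-c1ccc(C(C)(C)C)cc1`: 72 mL.min-1.g-1
- compound 3 `Cn1nc(CN2CCCC2)nc1-c1cccc(C2(C(F)(F)F)CC2)c1`: 144 mL.min-1.g-1

In this assay, compound 2 lies within the usual scatter of compound 3. It stands beyond the scatter from the remaining measured compound, as a 2.9-fold lower number from compound 1 to compound 2 (0.46 log units; beyond the scatter) shows. That modest step, the only one measured, puts tert-butyl in place of 1-(trifluoromethyl)cyclopropyl on an aromatic carbon.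

Compound 4 `CN(Cc1nc(-c2ccc(C(C)(C)C)cc2)n(C)n1)CC1CC1` changes a different place: (cyclopropylmethyl)(methyl)amino in place of pyrrolidin-1-yl on a saturated chain carbon bound to an aromatic carbon. Here (cyclopropylmethyl)(methyl)amino replaces pyrrolidin-1-yl on a saturated chain carbon bound to an aromatic carbon. For the measured compounds named here, no measured pair varies this amine, so the one step offers only a rough sense of scale and no direction. No step beyond the scatter is therefore expected, and the range is kept wide. The expected change is a 1.3-fold higher number from compound 2 to compound 4 (0.10 log units; within the scatter). For compound 4 the estimated value is 90 mL.min-1.g-1, with an expected range of 40 mL.min-1.g-1 to 200 mL.min-1.g-1.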

Compound 4, intrinsic clearance in microsomes: 196 mL.min-1.g-1
Beside the measured number, compound 4's estimate is 2.2-fold (0.34 log units) below it; the range from low to high includes it.
By their numbers in this assay, from the lowest: compounds 2, 3, 4 and 1 (each within the scatter of the next, the first and the last beyond it).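

In this assay, (cyclopropylmethyl)(methyl)amino in place of pyrrolidin-1-yl gives a 2.7-fold higher number from compound 2 to compound 4 (0.43 log units; beyond the scatter), so the amine on the saturated chain carbon also moves this read-out. For the compounds shown here, until now, the only measured step was a change in a different place, a 2.9-fold lower number from compound 1 to compound 2 (0.46 log units; beyond the scatter), and the new step runs towards faster clearance with tert-butyl held fixed. No available evidence accounts for this rise.

Going by these compounds, a single pair cannot separate the loss of the five-membered ring from the arrival of the cyclopropylmethyl and methyl groups, and it remains open how a simple dimethylamino or a morpholin-4-yl group would read in the same place. On these data alone, it is also open whether the step would carry over to the core of compound 1, which bears 1-(trifluoromethyl)cyclopropyl.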